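A few compounds are considered here, and "the series" means these few. Any claim that something is new, unique, unknown or untested is made for them only; others in the source may bear on it.

Compound 1 `Oc1cccc(-c2cc(-c3ccco3)cc(-c3ccccc3O)n2)c1` was tested in a functional assay on HeLa cells (Homo sapiens) for cytotoxicity, read by CCK-8 assay; on this read-out lower numbers stand for stronger inhibition and higher numbers for weaker inhibition. There compound 1 gives only a limit, > 50000 nM, and not a number. Compound 2 `Oc1ccc(-c2cc(-c3ccco3)cc(-c3ccccc3O)n2)cc1` likewise gives only a limit in this assay, > 50000 nM. Compound 3 `Oc1cccc(-c2cc(-c3ccco3)cc(-c3cccc(O)c3)n2)c1` gives a real number in this assay, 5990 nM. The step that the two limits leave unreadable from compound 1 to compound 2 stays unreadable because both values sit at the same limit (the limit of > 50000 nM in this assay, at which 2 of the 3 values shown sit). The step of an at least 8.3-fold lower number from compound 1 to compound 3 (0.92 log units; beyond the scatter) is the one readable change among these compounds. Compound 4 `Oc1cccc(-c2cc(-c3cccnc3)cc(-c3ccccc3O)n2)c1` differs from compound 1 in a different place: pyridin-3-yl in place of furan-2-yl on an aromatic carbon. Neither measured step touches the furan-2-yl group, so for the step that the limit leaves unreadable from compound 1 to compound 4 no change beyond the scatter is expected. Compound 4 is therefore estimated at 60000 nM, within a range from 15000 nM to 250000 nM, most likely again reported only as a limit.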

Compound 4, half-maximal inhibitory concentration: 7530 nM
For compound 4 the middle estimate is 8.0-fold (0.90 log units) above the measured one, outside the stated range (below it).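

The place opposite the ring nitrogen turns out not to be silent in this assay: swapping furan-2-yl for pyridin-3-yl gives an at least 6.6-fold lower number from compound 1 to compound 4 (0.82 log units; beyond the scatter). So a readable change no longer needs a shift of the hydroxyl group on a hydroxyphenyl ring, even though both groups count the same hydrogen-bond donors and acceptors. The true size of this step stays unknown because compound 1 gives only a limit: the limit of > 50000 nM in this assay, at which 2 of the 4 values shown sit.

From the compounds shown here alone, it remains open whether the ring's size or its nitrogen carries the step, which a plain phenyl group at this place would help to separate. Going by these compounds, whether pyridin-3-yl acts the same way with two 3-hydroxyphenyl groups also remains open.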